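A Weak Series and One Amide Swap

The source may hold more compounds than are shown below. What is called first, only, known or untested is meant among the compounds shown, and "the series" means these compounds.

Measured compounds:
Compound 1, `CN(c1ncccc1CNc1nc(Nc2ccccc2)nc2[nH]cc(F)c12)S(C)(=O)=O`, in a functional assay on SMMC-7721 cells (Homo sapiens) for inhibition, read by MTT assay, with a stated time of 48 h (a higher number here means a weaker inhibitor, a lower number a stronger inhibitor), reaches only the limit > 100000 nM.
Compound 2, `CN(c1ncccc1CNc1nc(Nc2ccc(F)c(Cl)c2)nc2[nH]cc(F)c12)S(C)(=O)=O`, likewise gives only the limit > 100000 nM.
Among the measured compounds shown here, compound 3, `COc1ccc(Nc2nc(NCc3cccnc3N(C)S(C)(=O)=O)c3c(F)c[nH]c3n2)cc1OC`, gives 54800 nM, the only true number here.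

Compound 3 therefore stands as the sole measurable point among three values, two of which sit at the limit of > 100000 nM in this assay, at which 2 of the 3 values shown sit. Compound 4, `CC(=O)Nc1cccc(Nc2nc(NCc3cccnc3N(C)S(C)(=O)=O)c3c(F)c[nH]c3n2)c1`, carries 3-acetamidophenyl in place of 3,4-dimethoxyphenyl on a nitrogen on an aromatic ring. The bearing steps are an at least 1.8-fold lower number from compound 1 to compound 3 (0.26 log units; that floor lies within the scatter) and an at least 1.8-fold lower number from compound 2 to compound 3 (0.26 log units; that floor lies within the scatter), both only floors and both within the scatter, while a step that the two limits leave unreadable from compound 1 to compound 2 says nothing readable. Changing the aryl group on this nitrogen has thus shown no step beyond the scatter, so the expected step of a 1.5-fold higher number from compound 3 to compound 4 (0.16 log units; within the scatter) in this assay is small, with a fair chance of another limit. Compound 4 is estimated at 80000 nM, within 30000 nM to 200000 nM.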

Compound 4, half-maximal inhibitory concentration: 16000 nM
Compound 4: middle estimate off by 5.0-fold (0.70 log units), on the high side; the measured number lies below the stated range.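

Among the compounds shown here, with 3-acetamidophenyl on this nitrogen, the series shows a 3.4-fold lower number from compound 3 to compound 4 (0.53 log units; beyond the scatter), the first step at this position that clears the scatter, so the aryl group here can change the reading after all. The same group also gives an at least 6.2-fold lower number from compound 2 to compound 4 (0.79 log units; beyond the scatter) and an at least 6.2-fold lower number from compound 1 to compound 4 (0.79 log units; beyond the scatter). Both of these steps are only floors, as compounds 1 and 2 each reach only a limit: the limit of > 100000 nM in this assay, at which 2 of the 4 values shown sit.

Going by these compounds, whether the step depends on the amide hydrogen or on the carbonyl stays open. So does whether a methanesulfonamido or an aminomethyl group on this phenyl ring would give a similar step.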